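From ethyl to tert-butyl on the shared core

This account rests on a few compounds, and the source may have more. Where it says the series, first, only, none or still open, it means among the compounds named here.

Measured in a functional assay on SK-MEL-28 cells (Homo sapiens) for inhibition, read by MTT assay, with a stated time of 72 h; on this read-out lower numbers stand for stronger inhibition of growth and higher numbers for weaker inhibition of growth:
compound 1 `COC(=O)/C=C/C1=CC[C@H]2C(C)(C)CCC[C@]2(C)[C@H]1C=O`: 27000 nM
compound 2 `CCOC(=O)/C=C/C1=CC[C@H]2C(C)(C)CCC[C@]2(C)[C@H]1C=O`: 29000 nM
compound 3 `CCOC(=O)/C(C)=C/C1=CC[C@H]2C(C)(C)CCC[C@]2(C)[C@H]1C=O`: 37000 nM

In this assay, compound 2 gives 29000 nM, within the scatter of both compound 1 and compound 3, so the three values form one tight group with no ranking among them.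

The next compound is compound 4 `CC(C)(C)OC(=O)/C=C/C1=CC[C@H]2C(C)(C)CCC[C@]2(C)[C@H]1C=O`, which carries tert-butyl in place of ethyl on an oxygen next to a carbonyl group.

Going by the values given here, one measured step bears on this change: a 1.1-fold higher number from compound 1 to compound 2 (0.03 log units; within the scatter). It concerns the same chain on that oxygen and stays within the scatter. The data hold no measured tert-butyl at this place, so this single step is a thin guide and the range has to stay generous. On that basis, no shift beyond the scatter is expected, and neither direction is favoured. The estimated step is a 1.0-fold higher number from compound 2 to compound 4 (0.01 log units; within the scatter). For compound 4 the estimated value is 30000 nM, with an expected range of 16000 nM to 55000 nM.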

Compound 4, concentration for 50% growth inhibition: 41000 nM
The estimate for compound 4 lay 1.4-fold (0.14 log units) below the measured number; the measured number falls inside the stated range.
By their numbers in this assay, from the lowest: compounds 1, 2, 3 and 4 (each within the scatter of the next).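

In this assay the step of a 1.4-fold higher number from compound 2 to compound 4 (0.15 log units; within the scatter) and the step of a 1.5-fold higher number from compound 1 to compound 4 (0.18 log units; within the scatter) both bring in tert-butyl on an oxygen next to a carbonyl group, replacing ethyl and methyl. Both steps stay within the scatter, so methyl, ethyl and tert-butyl at this place cannot be told apart on this read-out. The earlier step spanned only methyl and ethyl, whereas the comparison now also includes a branched group, and the four values still show no ranking.

Still open, going by these compounds, is whether a carboxylic acid, an amide or a longer chain in place of these esters would stay in the same group or give a step beyond the scatter. No supporting measurement is available to explain these values.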